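The compounds below may be only part of what the source reports. "The series", "measured", "known", "first", "only" and "open" are said of these compounds alone.

Series notes. Of the compounds shown here, two of this set have numbers so far. Compound 1 `Clc1ccc(-c2cn3nc(Cc4ccccc4)sc3n2)cc1` gives in a functional assay on cells (Cancer cell lines, Homo sapiens) for inhibition (on this read-out higher numbers stand for weaker inhibition of growth and lower numbers for stronger inhibition of growth), a value of 13800 nM. Compound 2 `O=Cc1c(-c2ccc(Br)cc2)nc2sc(Cc3ccccc3)nn12` gives in this assay 7400 nM. Compound 2 stands alongside compound 1: the gap between the two numbers lies within the usual scatter of repeated measurements, so the pair shows no real separation and neither can be set above the other on the evidence at hand. Among the compounds with values here, no pair of measured compounds differing in a single place exists within the set, so no measured step is available to lean on.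

The next member, compound 3 `O=Cc1c(-c2ccc([N+](=O)[O-])cc2)nc2sc(Cc3ccccc3)nn12`, differs from compound 2 in one place: nitro in place of bromo on an aromatic carbon. The change sits on the six-membered aromatic ring of carbon only, para to a large group, with the rest of the shared core untouched. Within the data shown here, with no measured step between compounds for guidance, the step is expected a 1.1-fold lower number from compound 2 to compound 3 (0.02 log units; within the scatter) and is taken as none beyond the scatter. Compound 3 is therefore estimated at 7000 nM, with a range from 2500 nM to 20000 nM, pending measurement.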

Compound 3, concentration for total growth inhibition: 26900 nM
Compound 3: middle estimate off by 3.8-fold (0.58 log units), on the low side, outside the stated range (above it).
By their numbers in this assay, from the lowest: compounds 2, 1 and 3 (each within the scatter of the next, the first and the last beyond it).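

The position on the six-membered aromatic ring of carbon only, para to a large group, now has its first measured step: in this assay, nitro in place of bromo on an aromatic carbon gives a 3.6-fold higher number from compound 2 to compound 3 (0.56 log units; beyond the scatter) and so lies beyond the scatter. On this read-out the higher number stands for weaker inhibition of growth, so this position is not indifferent to the group it carries, at least for this one exchange with the rest of the shared core untouched. No measured property of either group is at hand to account for the step, and one exchange does not show which difference between bromo and nitro matters.

Open, from the compounds shown here alone, is how other groups at this position would read, for example an amine, a carboxylic acid or a methoxy group, and whether any of them would give a lower number than bromo does in compound 2. Also open, going by these compounds, is whether the same exchange would give a step of similar size with a change elsewhere on the shared core, such as a longer chain in place of the benzyl group.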